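The compounds below may be only part of what the source reports. "The series", "measured", "known", "first", "only" and "open" are said of these compounds alone.

Of the compounds shown here, two have been read so far in an ADME assay on NIH3T3 cells (Mus musculus) for cytotoxicity; on this read-out lower numbers stand for an effect already at smaller amounts and higher numbers for an effect only at larger amounts of compound. Compound 1 `Cc1cc(C)cc(Oc2cccc(Cn3ccnc3)c2)c1` gives > 100000 nM, which is a limit of the assay and not a number. Among the measured compounds shown here, compound 2 `Cc1cc(Oc2cccc(Cn3ccnn3)c2)cc(C)c1Cl` gives 66800 nM, the only actual number available, so its place can't be ranked against a second measured figure. For the measured compounds named here, no step between two measured compounds is available either.

Compound 3 `Cc1nnc(-c2cccc(Oc3cc(C)c(Cl)c(C)c3)c2)s1` has not yet been measured in this assay. It carries 5-methyl-1,3,4-thiadiazol-2-yl in place of (1H-1,2,3-triazol-1-yl)methyl on an aromatic carbon of a six-membered aromatic ring of carbon only, meta to a large group: 5-methyl-1,3,4-thiadiazol-2-yl in place of (1H-1,2,3-triazol-1-yl)methyl on an aromatic carbon.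

Going by the values given here, with only the single number of compound 2 at 66800 nM to start from, no change beyond the usual scatter is expected in this assay, with a slight lean towards an effect at smaller amounts. The expected size of the change is a 1.7-fold lower number from compound 2 to compound 3 (0.22 log units; within the scatter), and this remains an estimate. For compound 3 the estimated value is 40000 nM, with an expected range from 12000 nM to 100000 nM.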

Compound 3, half-maximal effective concentration: > 100000 nM
Compound 3 was reported as a limit; the forecaster's own chance of this, stated with the estimate: 30%; at least 2.5-fold (0.39 log units) between middle value and limit.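

Among the compounds shown here, replacing (1H-1,2,3-triazol-1-yl)methyl with 5-methyl-1,3,4-thiadiazol-2-yl on an aromatic carbon gives the first step that can be read in this assay, and it is an at least 1.4-fold higher number from compound 2 to compound 3 (0.17 log units; that floor lies within the scatter). In this assay compound 3 gives > 100000 nM, which is a limit of the assay and not a number, so this step is only a floor, and the floor by itself does not establish a change beyond the scatter. What the change does show is that, with a five-membered aromatic ring with 3 hetero atoms on both sides and sulfur now among those atoms, this position tolerates the swap without the effect moving to smaller amounts, although the read-out has little room left at this end: the limit of > 100000 nM in this assay, at which 2 of the 3 values shown sit.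

On these data alone, the true distance between compound 2 and compound 3 stays open, as does whether the small effect seen for compound 2 belongs to the (1H-1,2,3-triazol-1-yl)methyl group or to the rest of the molecule. Also open, as far as these compounds go, is how this assay would respond to a primary amine or a carboxylic acid on the same aromatic carbon.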